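The source may hold more compounds than are shown below. What is called first, only, known or untested is meant among the compounds shown, and "the series" means these compounds.

Two members of the series carrying the shared core have numbers in a functional assay on the whole organism with Mus musculus as the target, in the maximal electroshock model, with a stated time of 0.5 h; on this read-out lower numbers stand for an effect already at smaller amounts and higher numbers for an effect only at larger amounts of compound. Compound 1 `Oc1ccc(/C=N/NC(=S)Nc2nc3ccc(Cl)cc3s2)cc1` gives 100 mg/kg in this assay. Compound 2 `CC(C)(C)NCC(=O)Nc1nc2ccc(Cl)cc2s1` gives 30 mg/kg in this assay, the lowest of the two numbers; its nearest neighbour is compound 1, whose number is higher by an amount beyond the scatter, so on these two points compound 2 is the more potent of the pair. Compound 3 `O=C(Cn1ccnc1)Nc1nc2ccc(Cl)cc2s1` has not yet been measured in this assay. Relative to compound 2 it differs in one place: 1H-imidazol-1-yl in place of (tert-butyl)amino on a saturated chain carbon bound to a carbonyl carbon. Among the compounds with values here, no pair of measured compounds shares this change, so nothing measured tells its size or direction. Compound 1 differs from compound 2 in several places at once and cannot serve as a guide either. The expectation for compound 3 therefore rests on compound 2 alone, and a step of no change at the digits printed from compound 2 to compound 3 (within the scatter) is expected, that is, no change beyond the scatter in either direction. Compound 3 is thus estimated at 30 mg/kg in this assay, with a range from 15 mg/kg to 100 mg/kg.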

Compound 3, minimum effective dose: 30 mg/kg
Beside the measured number, compound 3's estimate shows no gap at the digits printed; measured number inside the range.
By their numbers in this assay, from the lowest: compounds 2 and 3 (each within the scatter of the next); then compound 1.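

In this assay, the first step read at this place is no change at the digits printed from compound 2 to compound 3 (within the scatter), so on a saturated chain carbon bound to a carbonyl carbon, 1H-imidazol-1-yl and (tert-butyl)amino cannot be told apart on this read-out. The exchange is not a small one in its counts: both groups have 5 heavy atoms, but 1H-imidazol-1-yl brings one five-membered aromatic ring with 2 hetero atoms and 0 hydrogen-bond donors, whereas (tert-butyl)amino has no ring and 1 hydrogen-bond donor, so in this one pair neither that donor nor the absence of a ring is required for a number within the scatter. Nothing at hand accounts for the two groups reading alike in this assay.

Going by these compounds, whether other groups at this place read the same stays open, for example a morpholine ring, a carboxylic acid, or a longer chain in place of the saturated chain carbon. Also open, on these data alone, is whether the pair would still read alike with fluoro in place of the chloro group on the shared core.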